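The compounds below may be only part of what the source reports. "The series", "measured", "known", "first", "only" and "open" are said of these compounds alone.

Compound 1 `Cc1cc(C(=O)Nc2cccc(-c3ccnc4c(N)cccc34)c2)ccc1Br` and compound 2 `Nc1cccc2c(-c3cccc(NC(=O)c4cccc(C(F)(F)F)c4)c3)ccnc12` share a core and differ on a carbonyl carbon: 3-(trifluoromethyl)phenyl in place of 4-bromo-3-methylphenyl on a carbonyl carbon. In a functional assay on A375P cells (Homo sapiens) for antiproliferative activity, read by MTT assay, with a stated time of 48 h (on this read-out higher numbers stand for weaker inhibition and lower numbers for stronger inhibition), compound 1 gives 9900 nM. In this assay compound 2 gives 7900 nM. The step of a 1.3-fold lower number from compound 1 to compound 2 (0.10 log units; within the scatter) is within the scatter of repeated measurement.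

Compound 3 `CC(=O)Nc1cccc2c(-c3cccc(NC(=O)c4ccc(Br)c(C)c4)c3)ccnc12` differs from compound 1 in the core, on a nitrogen on an aromatic ring: acetyl in place of hydrogen on a nitrogen on an aromatic ring. In this assay compound 3 reaches only a limit of the assay, > 20000 nM. The step of an at least 2.0-fold higher number from compound 1 to compound 3 (0.30 log units; that floor lies within the scatter) is therefore a floor rather than a number, and this floor is the limit of > 20000 nM in this assay, at which 1 of the 3 values shown sits.

Compound 4 `CC(=O)Nc1cccc2c(-c3cccc(NC(=O)c4cccc(C(F)(F)F)c4)c3)ccnc12` stands to compound 3 as compound 2 stands to compound 1, the same change made on the acetamido core: 3-(trifluoromethyl)phenyl in place of 4-bromo-3-methylphenyl on a carbonyl carbon. Because the earlier step of a 1.3-fold lower number from compound 1 to compound 2 (0.10 log units; within the scatter) did not move the number beyond the scatter, the step from compound 3 to compound 4 in this assay is expected to be small as well, about a step that the limit leaves unreadable from compound 3 to compound 4. Compound 4 is accordingly estimated at 25000 nM, with a range from 12000 nM to 60000 nM, and it is expected that the assay may again report only a limit for compound 4.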

Compound 4, half-maximal inhibitory concentration: 8000 nM
Compound 4: middle estimate off by 3.1-fold (0.49 log units), on the high side, outside the stated range (below it).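

Carried onto the acetamido core, the change to 3-(trifluoromethyl)phenyl on the carbonyl carbon gives an at least 2.5-fold lower number from compound 3 to compound 4 (0.39 log units; beyond the scatter) in this assay, but this step is only a floor, since compound 3 rests on a limit of the assay: the limit of > 20000 nM in this assay, at which 1 of the 4 values shown sits. The step beyond the scatter therefore does not show that the change acts differently on the two cores, nor does it show that it acts alike: the same change on two cores in this assay, a 1.3-fold lower number (0.10 log units; within the scatter) from compound 1 to compound 2 and an at least 2.5-fold lower number (0.39 log units; beyond the scatter) from compound 3 to compound 4; the limit leaves it open whether they differ. With 3-(trifluoromethyl)phenyl held in place, acetyl on the nitrogen gives a 1.0-fold higher number from compound 2 to compound 4 (0.01 log units; within the scatter), which stays within the scatter, and this one pair does not settle how acetyl behaves with 4-bromo-3-methylphenyl on the carbonyl carbon: the same change on two cores in this assay, an at least 2.0-fold higher number (0.30 log units; that floor lies within the scatter) from compound 1 to compound 3 and a 1.0-fold higher number (0.01 log units; within the scatter) from compound 2 to compound 4; the limit leaves it open whether they differ.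

The compounds shown leave open how large the step to compound 4 truly is, as no number stands behind the limit of compound 3. They also leave open how a longer acyl chain in place of the acetyl, or a pyridine ring in place of the phenyl on the carbonyl carbon, would read in this assay.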